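Fluoro for hydrogen on a benzyl ring, two sulfonamide cores

The compounds below may be only part of what the source reports. "The series", "measured", "known", "first", "only" and "open" are said of these compounds alone.

Measured so far in a functional assay on 3T3-L1 cells (Mus musculus) for inhibition, with a stated time of 20 min, tested at 20 uM; on this read-out higher numbers stand for more inhibition at the one concentration tested (going by the name of the read-out) and lower numbers for less inhibition:
compound 1, `Cc1ccc(S(=O)(=O)n2cc(CN(Cc3cn(Cc4ccccc4)nn3)S(=O)(=O)c3ccccc3)c3ccccc32)cc1`, gives -18%
compound 2, `Cc1ccc(S(=O)(=O)N(Cc2ccccc2)Cc2cccc(F)c2F)cc1`, gives -35.7%
compound 3, `Cc1ccc(S(=O)(=O)n2cc(CN(Cc3cn(Cc4ccc(F)cc4)nn3)S(=O)(=O)c3ccccc3)c3ccccc32)cc1`, gives -21%

Compound 1 and compound 3 share one core and differ only by fluoro in place of hydrogen on an aromatic carbon. In this assay this change gives a number 3 percentage points lower from compound 1 to compound 3 (within the scatter), so within the scatter compound 1 and compound 3 are not separable. Compound 2 rests on a different core; the difference between the two cores is not broken down here. Compound 2 stands lowest of the three numbers: compound 3 lies a step above it that is beyond the scatter, and compound 1 lies further above it, also beyond the scatter.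

Compound 4, `Cc1ccc(S(=O)(=O)N(Cc2ccc(F)cc2)Cc2cccc(F)c2F)cc1`, is not yet measured. It differs from compound 2 by fluoro in place of hydrogen on an aromatic carbon, the same change as that from compound 1 to compound 3, at a place described in the same words. Among the compounds with values here, the only measured instance of this change, a number 3 percentage points lower from compound 1 to compound 3 (within the scatter), lies within the scatter. The expectation for compound 4 therefore rests on that single pair and on the value of compound 2, -35.7%: a step of about a number 2.3 percentage points lower from compound 2 to compound 4 (within the scatter) is expected, because a number 3 percentage points lower from compound 1 to compound 3 (within the scatter) gave no movement beyond the scatter. Compound 4 is estimated at -38%, expected to fall between -54% and -22%. Within the data shown here, only two compounds carry this change, so this remains a guess carried over from one core to another.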

Compound 4, a percentage reported as inhibition, at one concentration (the size of the read-out at that concentration, not a potency): -97.7%
Compound 4: middle estimate off by 59.7 percentage points, on the high side, outside the stated range (below it).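

In this assay, fluoro in place of hydrogen on an aromatic carbon does not give a step of the same size on the two cores: the same change on two cores in this assay, a number 3 percentage points lower (within the scatter) from compound 1 to compound 3 and a number 62 percentage points lower (beyond the scatter) from compound 2 to compound 4, 59 percentage points apart, beyond the scatter of two such steps

On the second core, this single change gives a number 62 percentage points lower from compound 2 to compound 4 (beyond the scatter), so a step read on one core is no safe guide to the same change on the other in this series. Within the data shown here, the comparison rests on only two pairs, one per core, and the cores differ in more than one place, so it does not show which feature of the cores separates the two steps, nor whether the large step would recur on any further core.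

Open, going by these compounds, is whether chloro, methoxy or a carboxylic acid on the same ring, para to a large group, would move the number on the core of compound 2 as far as fluoro does, or would leave it within the scatter as on the core of compound 1. Also open, on these data alone, is whether the step on the core of compound 2 keeps its size when the other benzyl group on that core carries no fluoro.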